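Replacing a Hydroperoxide Chain End in a Triterpenoid Series

A few compounds are considered here, and "the series" means these few. Any claim that something is new, unique, unknown or untested is made for them only; others in the source may bear on it.

Measured compounds:
Compound 1 `CC1=CC[C@H]2[C@@H]1CC=C(C)[C@@H](CC[C@H]1[C@]3(C)CC[C@H](O)C(C)(C)O[C@H]3CC[C@@]1(C)O)C2(C)C` gives > 50000 nM in a functional assay on MDA-MB-231 cells (Homo sapiens) for antiproliferative activity, read by MTT assay, with a stated time of 72 h (a higher number here means a weaker inhibitor, a lower number a stronger inhibitor), a limit rather than a number.
Compound 2 `CC1=CC[C@H]2[C@H](CC[C@]2(C)O)C(C)(C)[C@@H]1CC[C@H]1[C@]2(C)CC[C@H](OC(=O)c3cccc([N+](=O)[O-])c3)C(C)(C)O[C@H]2CC[C@@]1(C)O` gives 34700 nM in this assay.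
Compound 3 `C=C(C)C(CC[C@@]1(C)C(CC[C@H]2[C@]3(C)CC[C@H](O)C(C)(C)O[C@H]3CC[C@@]2(C)O)=C(C)CC[C@H]1O)OO` gives > 50000 nM in this assay, again a limit rather than a number.

Compound 3 therefore stands at the weak end of what has been measured. Among the measured compounds shown here, its value in this assay is only a limit, and of the three values shown, two sit at that same limit (the limit of > 50000 nM in this assay, at which 2 of the 3 values shown sit), so compound 3 cannot be placed above or below compound 1, and the value of compound 2 is the only number that has been resolved at all.

Compound 4 `CC(C)=CCC[C@@]1(C)C(CC[C@H]2[C@]3(C)CC[C@H](O)C(C)(C)O[C@H]3CC[C@@]2(C)O)=C(C)CC[C@H]1O` is the unmeasured partner of compound 3. The difference between the two is a group of 4 heavy atoms (4 carbon; no ring) in place of a group of 6 heavy atoms (4 carbon, 2 oxygen; no ring), on a saturated chain carbon, two bonds along the chain from a saturated ring carbon. For the measured compounds named here, no measured pair in this set differs in one place, so no step has been observed that would tell how such an exchange shifts this assay. With compound 3 already at the limit of this assay, the step of a number no higher from compound 3 to compound 4 (the limit leaves the size open) is expected to be no larger than the scatter, and compound 4 is estimated at 50000 nM, with a range from 20000 nM to 100000 nM, most likely reported again only as a limit.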

Compound 4, half-maximal inhibitory concentration: > 50000 nM
Compound 4 ended at the assay's limit (the forecaster's own chance of this, stated with the estimate: 70%); the middle value lies on the limit itself.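

Compound 3 and compound 4 both end at a limit rather than a number, so no step can be read between them in this assay: the limit of > 50000 nM in this assay, at which 3 of the 4 values shown sit.

The compounds shown leave open whether putting 2-methylprop-1-en-1-yl in place of the hydroperoxide chain end shifts activity in this assay at all, and in which direction.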